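Ester to benzyl tetrazole on the shared core

The compounds below may be only part of what the source reports. "The series", "measured", "known", "first", "only" and "open" are said of these compounds alone.

Within the data shown here, compound 3 `COC(=O)c1ccccc1-c1ccc(CN2C(=O)[C@H](NC(=O)CC(C)(C)N)CCc3ccccc32)cc1` gives 2 uM in a functional assay (Pituitary gland cell) with Rattus norvegicus as the target (on this read-out lower numbers stand for an effect already at smaller amounts and higher numbers for an effect only at larger amounts of compound), the highest of the three numbers measured so far; compound 1 `CC(C)(N)CC(=O)N[C@@H]1CCc2ccccc2N(Cc2ccc(-c3ccccc3-c3nnnn3CC(=O)O)cc2)C1=O` gives 1 uM, which lies within the scatter of compound 3, while compound 2 `Cn1nnc(-c2ccccc2-c2ccc(CN3C(=O)[C@H](NC(=O)CC(C)(C)N)CCc4ccccc43)cc2)n1` gives 0.3 uM, beyond it.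

Compound 4 `CC(C)(N)CC(=O)N[C@@H]1CCc2ccccc2N(Cc2ccc(-c3ccccc3-c3nnn(Cc4ccccc4)n3)cc2)C1=O` differs from compound 3 by 2-benzyl-2H-tetrazol-5-yl in place of methoxycarbonyl on an aromatic carbon, on an aromatic carbon ortho to a large group. The step of a 6.7-fold higher number from compound 2 to compound 3 (0.82 log units; beyond the scatter) bears most directly on this change, as it runs the same exchange backwards with a methyl rather than a benzyl on the tetrazole; the step of a 2.0-fold higher number from compound 1 to compound 3 (0.30 log units; within the scatter) stayed within the scatter. Among the measured compounds shown here, the benzyl itself has no measured counterpart.

A modest lower number is therefore expected, a 4.0-fold lower number from compound 3 to compound 4 (0.60 log units; beyond the scatter). Compound 4 is estimated at 0.5 uM, with a range of 0.15 uM to 1.5 uM.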

Compound 4, concentration for half-maximal effect: 1 uM
Compound 4: the middle estimate sits 2.0-fold (0.30 log units) below what was measured, and the stated range covers the measured number.
By their numbers in this assay, from the lowest: compound 2; then compounds 1, 4 and 3 (each within the scatter of the next).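

In this assay the exchange of methoxycarbonyl for 2-benzyl-2H-tetrazol-5-yl gives a 2.0-fold lower number from compound 3 to compound 4 (0.30 log units; within the scatter) and so, unlike the methyl tetrazole of compound 2, does not separate from the ester. The substituent on the tetrazole nitrogen therefore matters at this position: phenyl in place of hydrogen on that chain carbon gives a 3.3-fold higher number from compound 2 to compound 4 (0.52 log units; beyond the scatter) as the step. The two larger tetrazole groups read alike, with no change at the digits printed from compound 1 to compound 4 (within the scatter) between the 1-(carboxymethyl)-1H-tetrazol-5-yl and the 2-benzyl-2H-tetrazol-5-yl.

No measurement here bears on the reason for the methyl-to-benzyl step. On these data alone, how an ethyl or a longer chain carrying an amine on that tetrazole nitrogen would read remains open.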